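Five-membered ring swap on the shared core

A few compounds are considered here, and "the series" means these few. Any claim that something is new, unique, unknown or untested is made for them only; others in the source may bear on it.

Compound 1 `CCn1ccc(-c2ccccc2NCC2=NCCN2)n1`, compound 2 `Cn1cccc1-c1ccccc1NCC1=NCCN1` and compound 3 `CC(C)n1nccc1-c1ccccc1NCC1=NCCN1` differ only in the five-membered aromatic ring attached to the shared core. In a functional assay with Alpha-1B adrenergic receptor (Homo sapiens) as the target, read by calcium flux (on this read-out lower numbers stand for smaller maximal responses and higher numbers for larger maximal responses), compound 1 gives 0%, compound 2 gives 0% and compound 3 gives 0%. Compound 2 thus stands level with compound 1 and with compound 3 at the digits reported; its nearest neighbour is compound 1 and its furthest compound 3, and neither pair is separated beyond the usual scatter, so no order among the three can be stated. Among the compounds with values here, no single-change step between two measured compounds is available in this set.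

Compound 4 `Cn1nccc1-c1ccccc1NCC1=NCCN1` differs from compound 2 in one place: 1-methyl-1H-pyrazol-5-yl in place of 1-methyl-1H-pyrrol-2-yl on an aromatic carbon. Nothing measured here speaks for a change of the maximal response with such a swap, since compound 1 with 0%, compound 2 with 0% and compound 3 with 0% carry three different five-membered rings and all read the same. The expected step is no change at the digits printed from compound 2 to compound 4 (within the scatter), none beyond the scatter. For compound 4 the estimated maximal response in this assay is 0%, with an expected range from 0% to 10%.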

Compound 4, largest response reached (reported as maximal response), in percent of the reference or control that the assay uses: 0%
Beside the measured number, compound 4's estimate shows no gap at the digits printed; the measured number falls inside the stated range.
By their numbers in this assay, from the lowest: compounds 1, 2, 3 and 4 (each within the scatter of the next).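

In this assay, within the data shown here, the swap of 1-methyl-1H-pyrrol-2-yl for 1-methyl-1H-pyrazol-5-yl on an aromatic carbon reads as no change at the digits printed from compound 2 to compound 4 (within the scatter) and gives a single-change reading at this position, which the earlier compounds did not provide. Methyl in place of isopropyl on an aromatic nitrogen reads as no change at the digits printed from compound 3 to compound 4 (within the scatter) and shows that, for this pair, the size of that nitrogen substituent can be changed alone with no step beyond the scatter. No supporting data explain why either step stays flat.

Both steps connect compounds at the same reading, so neither shows which change, if any, could raise the maximal response from this level. From the compounds shown here alone, whether an amine or a carboxylic acid on the five-membered ring, or a longer chain such as n-butyl on its nitrogen, would give a response in this assay remains open.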